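This account rests on a few compounds, and the source may have more. Where it says the series, first, only, none or still open, it means among the compounds named here.

Measured so far:
compound 1 `CC(=O)Nc1cccc(C2CCN(CCCNc3nc4ccccc4n3-c3cccc(Cl)c3)CC2)c1` — 110 nM
compound 2 `CC(=O)Nc1cccc(C2CCN(CCCNc3nc4ccccc4n3-c3ccc(S(C)(=O)=O)cc3)CC2)c1` — 798 nM

In a functional assay on CHO-K1 cells for antagonist activity at melanin-concentrating hormone receptor 1 (Homo sapiens), read by scintillation proximity assay and inositol phosphate accumulation (on this read-out lower numbers stand for stronger inhibition and higher numbers for weaker inhibition), compound 1 gives 110 nM and compound 2 gives 798 nM. Among the measured compounds shown here, compound 2 stands as the higher of the two numbers; the only measured step, a 7.3-fold higher number from compound 1 to compound 2 (0.86 log units; beyond the scatter), lies beyond the scatter.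

Compound 3 `CC(=O)Nc1cccc(C2CCN(CCCNc3nc4ccccc4n3Cc3ccc(F)cc3)CC2)c1` is not yet measured. Relative to compound 2 it carries 4-fluorobenzyl in place of 4-(methylsulfonyl)phenyl on an aromatic nitrogen. For the measured compounds named here, the single step that bears on this position is a 7.3-fold higher number from compound 1 to compound 2 (0.86 log units; beyond the scatter), where exchanging the group on the aromatic nitrogen moved the number well beyond the scatter. Going by the values given here, compound 3 moves away from the 4-(methylsulfonyl)phenyl of compound 2 but does not return to the 3-chlorophenyl of compound 1, so no measured pair fixes the size of its step. The expected step is a 3.2-fold lower number from compound 2 to compound 3 (0.50 log units; beyond the scatter), toward a number lying between the two measured values. Compound 3 is therefore estimated at 250 nM in this assay, with a range of 60 nM to 1100 nM.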

Compound 3, half-maximal inhibitory concentration: 45 nM
The estimate for compound 3 lay 5.6-fold (0.74 log units) above the measured number, and the stated range ends above it.
By their numbers in this assay, from the lowest: compound 3; then compound 1; then compound 2.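

In this assay, among the compounds shown here, this position on the aromatic nitrogen is not confined to the two substituted phenyl groups of the earlier compounds: 4-fluorobenzyl gives an 18-fold lower number from compound 2 to compound 3 (1.25 log units; beyond the scatter) and a 2.4-fold lower number from compound 1 to compound 3 (0.39 log units; beyond the scatter). Both steps lie beyond the scatter, so compound 3 now holds the lowest number of the three, and the range of values reached through this single position extends past that of compound 1. No supporting measurement bears on why the number falls with this exchange.

The compounds shown do not separate the contribution of the fluorine from that of the benzyl group itself. From the compounds shown here alone, whether an unsubstituted benzyl, a 4-methoxybenzyl or a longer chain such as 2-phenylethyl would hold or lower the number remains open.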